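A few compounds are considered here, and "the series" means these few. Any claim that something is new, unique, unknown or untested is made for them only; others in the source may bear on it.

In a functional assay on MCF7 cells (Homo sapiens) for inhibition, read by colorimetric assay and sulforhodamine B assay, with a stated time of 48 h (on this read-out higher numbers stand for weaker inhibition of growth and lower numbers for stronger inhibition of growth), compound 1 `CCCCCCCCCCCC[C@@H](O)[C@H]1CC[C@H]([C@H](O)CCCCCCCCCCNC(=O)c2ccco2)O1` gives 100000 nM and compound 3 `CCCCCCCCCCCC[C@@H](O)[C@H]1CC[C@H]([C@H](O)CCCCCCCCCCNC(=O)c2cncs2)O1` gives 100000 nM at the digits shown, so these two sit level as the highest of the three numbers. Compound 2 `CCCCCCCCCCCC[C@@H](O)[C@H]1CC[C@H]([C@H](O)CCCCCCCCCCNC(=O)c2ccoc2)O1` stands lower at 26900 nM on the same read-out. Compound 4 `CCCCCCCCCCCC[C@@H](O)[C@H]1CC[C@H]([C@H](O)CCCCCCCCCCNC(=O)c2ccsc2)O1` has thiophen-3-yl in place of 1,3-thiazol-5-yl on a carbonyl carbon and is otherwise identical to compound 3. Among the measured steps, furan-3-yl brought a 3.7-fold lower number from compound 1 to compound 2 (0.57 log units; beyond the scatter) and 1,3-thiazol-5-yl brought no change at the digits printed from compound 1 to compound 3 (within the scatter) when each replaced furan-2-yl. Replacing furan-3-yl with 1,3-thiazol-5-yl brought a 3.7-fold higher number from compound 2 to compound 3 (0.57 log units; beyond the scatter) and so undid that modest gain. By name, thiophen-3-yl reads closest to the furan-3-yl of compound 2, so a modest move towards a lower number is expected. The expected step is a 2.5-fold lower number from compound 3 to compound 4 (0.40 log units; beyond the scatter) in this assay. Compound 4 is estimated at 40000 nM, with an expected range of 15000 nM to 100000 nM.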

Compound 4, concentration for 50% growth inhibition: 2000 nM
Compound 4: middle estimate off by 20-fold (1.30 log units), on the high side; the measured number lies below the stated range.
By their numbers in this assay, from the lowest: compound 4; then compound 2; then compounds 1 and 3 (each within the scatter of the next).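

In this assay, the ring on this carbonyl carbon turns out to matter far more than the two furans and the thiazole suggested: thiophen-3-yl brings a 50-fold lower number from compound 3 to compound 4 (1.70 log units; beyond the scatter), as well as a 13-fold lower number from compound 2 to compound 4 (1.13 log units; beyond the scatter) and a 50-fold lower number from compound 1 to compound 4 (1.70 log units; beyond the scatter). Sulfur in the ring is not enough on its own, since compound 3 also carries it; the step from thiazole to thiophene swaps only a ring nitrogen for carbon. Nothing available here explains the size of these steps. As far as these compounds go, whether thiophen-2-yl or a plain phenyl ring on the same carbonyl carbon would match compound 4 remains open.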